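Swapping the aryl ether in a thymine-bearing piperidine series

The source may hold more compounds than are shown below. What is called first, only, known or untested is meant among the compounds shown, and "the series" means these compounds.

Measured so far:
compound 1 `COc1ccc(Oc2cccc(CN3CCC(n4cc(C)c(=O)[nH]c4=O)CC3)c2)cc1`: 28000 nM
compound 2 `Cc1cn(C2CCN(Cc3cccc(Oc4ccc(O)cc4)n3)CC2)c(=O)[nH]c1=O`: "not determined" (no result reported)

In an ADME assay on MRC5 cells (Homo sapiens) for cytotoxicity, read by fluorescence and resazurin assay, with a stated time of 3 days (a higher number here means a weaker inhibitor, a lower number a stronger inhibitor), compound 1 gives 28000 nM. Compound 1 holds the only number shown; compound 2 was entered in this assay but gives only "not determined" (no result reported), so compound 1 cannot be placed against anything else. Compound 3 `Cc1cn(C2CCN(Cc3cccc(Oc4cccc(OC(F)(F)F)c4)c3)CC2)c(=O)[nH]c1=O` has not yet been measured. It differs from compound 1 by 3-(trifluoromethoxy)phenyl in place of 4-methoxyphenyl on an oxygen on an aromatic ring. Within the data shown here, no step between two measured compounds is available to show what such a change does here, so the expectation rests on compound 1 alone. A step of no more than the usual scatter, or a slight move towards a stronger effect, is expected in this assay, as a 1.4-fold lower number from compound 1 to compound 3 (0.15 log units; within the scatter). Compound 3 is therefore estimated at 20000 nM, within the range 7000 nM to 60000 nM.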

Compound 3, half-maximal inhibitory concentration: 5260 nM
For compound 3 the middle estimate is 3.8-fold (0.58 log units) above the measured one; the whole stated range lies above it.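

In this assay, 3-(trifluoromethoxy)phenyl in place of 4-methoxyphenyl on the oxygen gives a 5.3-fold lower number from compound 1 to compound 3 (0.73 log units; beyond the scatter), the first sign that the group held at this position can shift the reading by more than repeat measurements would. Since a lower number means a stronger effect on the cells, compound 3 acts more strongly than compound 1, even though the shared core is unchanged. Nothing measured here explains why the number fell.

This one step alters both the substituent and its place on the ring, so the effect of each remains unresolved: 4-(trifluoromethoxy)phenyl or 3-methoxyphenyl would help to separate them. On these data alone, it also remains open whether a different group on this ring, such as an amine or a carboxylic acid, would move the number further or reverse the shift.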